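The source may hold more compounds than are shown below. What is called first, only, known or untested is meant among the compounds shown, and "the series" means these compounds.

In an ADME assay on HS27 cells (Homo sapiens) for cytotoxicity, read by MTT assay, with a stated time of 24 h (a higher number here means a weaker inhibitor of growth, a lower number a stronger inhibitor of growth), compound 1 `Cc1cc(NC(=O)Nc2cccc(Cl)c2)ccc1NC(=O)c1cnoc1C` gives > 30000 nM, which is a limit of the assay and not a number. Compound 2 `Cc1cc(NC(=O)Nc2ccccc2F)ccc1NC(=O)c1cnoc1C` gives > 30000 nM, which is also a limit. Both measured compounds therefore stand in the same place: the limit of > 30000 nM in this assay, at which 2 of the 2 values shown sit. Within the data shown here, the only measured change to this group is a step that the two limits leave unreadable from compound 1 to compound 2, so it offers no size to carry forward.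

Compound 3 `Cc1cc(NC(=O)Nc2ccc(Cl)c(Cl)c2)ccc1NC(=O)c1cnoc1C` brings one further change, (3,4-dichlorophenyl in place of 2-fluorophenyl on an amide-type nitrogen). It has 3,4-dichlorophenyl in place of 2-fluorophenyl on an amide-type nitrogen. With no readable step to draw on, no shift in either direction beyond the scatter can be argued, and compound 3 may well stay at the limit too. The expected change is a number no higher from compound 2 to compound 3 (the limit leaves the size open). In this assay, the estimate for compound 3 is 30000 nM, with an expected range from 12000 nM to 60000 nM.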

Compound 3, concentration for 50% growth inhibition: > 30000 nM
Compound 3 was reported as a limit; the forecaster's own chance of this, stated with the estimate: 70%; the middle value lies on the limit itself.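

Among these compounds, compound 1, compound 2 and compound 3 are all reported only as a limit of the assay and not as a number, so no step between them can be read: the limit of > 30000 nM in this assay, at which 3 of the 3 values shown sit.

As far as these compounds go, how strongly any of them inhibits growth in this assay, and whether changing the substituted phenyl group matters there, stays open.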